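Thiazole aryl swap on the pyrazole-carboxylic acid series

The source may hold more compounds than are shown below. What is called first, only, known or untested is meant among the compounds shown, and "the series" means these compounds.

Compound 1 `Cc1ccc(-c2c(C)nn(-c3nc(-c4ccc(Cl)c(Cl)c4)c(SC(C)C)s3)c2C(=O)O)cc1` gives 3800 nM in a functional assay on BJAB cells (Homo sapiens) for antiproliferative activity, with a stated time of 4 days; on this read-out higher numbers stand for an effect only at larger amounts of compound and lower numbers for an effect already at smaller amounts. Compound 2 `Cc1c(-c2cc(Cl)cc(Cl)c2)c(C(=O)O)nn1-c1nc(-c2cccnc2)c(SC(C)C)s1` is reported in this assay only as "not active" (no number reported), without a number, so no single value stands for it. Compound 3 `Cc1c(-c2cc(Cl)cc(Cl)c2)c(C(=O)O)nn1-c1nc(-c2cnn(C)c2)c(SC(C)C)s1` carries 1-methyl-1H-pyrazol-4-yl in place of pyridin-3-yl on an aromatic carbon, that is, 1-methyl-1H-pyrazol-4-yl in place of pyridin-3-yl on an aromatic carbon. Going by the values given here, no measured step links these two compounds, and nothing among the measured compounds points to a change beyond the scatter in either direction. Compound 3 is therefore expected to remain weak, around 12000 nM with a range of 3000 nM to 40000 nM, with a fair chance that only a limit is reported.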

Compound 3, half-maximal effective concentration: "not active" (no number reported)
No number was reported for compound 3; no gap can be computed for the estimate.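

Compound 2 and compound 3 are both reported only as not active, without a number, so no step can be read between them. Going by these compounds, how pyridin-3-yl and 1-methyl-1H-pyrazol-4-yl compare on this core remains open. No measured data bear on this result.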